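Kinase activators: trimming the ring nitrogen substituent

The source may report more compounds than this note shows. Statements on the series, on what has been measured and on what is new or still open speak of the compounds shown alone.

Two compounds of the series have numbers in an assay on isolated protein for activation of cGMP-dependent protein kinase 1 (Homo sapiens), read by ADP-Glo, with stated times of 120 min and 40 min; a lower number here means that less compound is needed, a higher number that more compound is needed for the effect. Compound 1 `Clc1cc(Cl)cc(CO[C@H]2CCCN(Cc3cccnc3)[C@H]2c2ccccc2)c1` gives 112000 nM in this assay. Compound 2 `OC[C@@H](O[C@H]1CCCN(Cc2ccccc2Cc2nnco2)[C@H]1c1ccccc1)c1cc(Cl)cc(Cl)c1` gives 3700 nM in this assay, the lowest of the two numbers; its nearest neighbour is compound 1, whose number is higher by a margin beyond the scatter. Among the measured compounds shown here, the two differ in several places at once, so no single-point step between them can be drawn.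

Compound 3 `CN1CCC[C@H](O[C@H](CO)c2cc(Cl)cc(Cl)c2)[C@@H]1c1ccccc1` is the next compound to be measured in this assay. Compared with compound 2 it carries a hydrogen atom in place of a group of 12 heavy atoms (9 carbon, 2 nitrogen, 1 oxygen; one five-membered aromatic ring with 3 hetero atoms, one six-membered aromatic ring of carbon only), on a saturated chain carbon bound to an amine nitrogen in a ring. The change strips away the larger part of what compound 2 bears on the amine nitrogen in the ring and keeps only the remaining methyl.

For the measured compounds named here, no measured pair shows the effect of this kind of removal. Since compound 2 stands as the lowest number and a group of this size is taken away, a step of an 11-fold higher number from compound 2 to compound 3 (1.03 log units; beyond the scatter) toward a higher number is expected, beyond the scatter. For compound 3 the expected value in this assay is 40000 nM, with a range from 8000 nM to 200000 nM.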

Compound 3, half-maximal effective concentration: 42000 nM
Estimate against measurement, compound 3: 1.1-fold (0.02 log units) below; the measured number falls inside the stated range.
By their numbers in this assay, from the lowest: compound 2; then compound 3; then compound 1.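

In this assay, among the compounds shown here, taking the group of 12 heavy atoms off the saturated chain carbon bound to the amine nitrogen in the ring gives an 11-fold higher number from compound 2 to compound 3 (1.06 log units; beyond the scatter), the only comparison so far that isolates a single place. This shows that the substituent at this position has a large bearing on the number, and that the five-membered aromatic ring with 3 hetero atoms and the six-membered aromatic ring of carbon only, taken together, are worth keeping in this series. It also shows that the group is not required for a reading, as compound 3 still gives 42000 nM with only the methyl left on the nitrogen, and no measurement at hand accounts for the size of this step.

The compounds shown do not separate the contributions of the two aromatic rings, as a plain benzyl group on the nitrogen would, and compound 1 differs from the others in more than one place, so it cannot settle this. As far as these compounds go, how an ethyl group, a longer alkyl chain or a carboxylic acid at the end of such a chain would read at this position remains open.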